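Swapping an Aminophenyl for a Dichlorophenyl on a Carbonyl

A few compounds are considered here, and "the series" means these few. Any claim that something is new, unique, unknown or untested is made for them only; others in the source may bear on it.

Measured so far:
compound 1, `COc1ccc(-c2cc(/C=C/C(=O)c3ccc(N)cc3)[nH]n2)cc1`, 100%
compound 2, `COc1cc(-c2cc(/C=C/C(=O)c3ccc(N)cc3)[nH]n2)cc(OC)c1OC`, 97%

In a functional assay on RPMI-8226 cells (Homo sapiens) for cytotoxicity, read by sulforhodamine B assay, with a stated time of 48 h, tested at 0.1 uM (a lower number here means a stronger effect, a higher number a weaker effect of the compound at the concentration tested), compound 1 gives 100%, and compound 2 gives 97%. The two numbers lie within the scatter of each other, so the data show no difference between compound 1 and compound 2 in this assay; both read-outs sit at the level where the cells are essentially unaffected at the concentration tested.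

Compound 3, `COc1cc(-c2cc(/C=C/C(=O)c3ccc(Cl)c(Cl)c3)[nH]n2)cc(OC)c1OC`, has not yet been measured. It differs from compound 2 in one place:

3,4-dichlorophenyl in place of 4-aminophenyl on a carbonyl carbon

Going by the values given here, no step between measured compounds is available for this exchange, so the expectation rests only on the two numbers in hand, both of which sit at the top of the read-out. Compound 3 is expected to remain near that level, with a step of a number 4 percentage points lower from compound 2 to compound 3 (within the scatter) that stays within the scatter or moves the read-out only slightly downward. The estimate for compound 3 is therefore 93%, with a range from 72% to 108%.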

Compound 3, a percentage reported as activity, at one concentration (the size of the read-out at that concentration, not a potency): 95%
Compound 3: middle estimate off by 2 percentage points, on the low side; measured number inside the range.
By their numbers in this assay, from the lowest: compounds 3, 2 and 1 (each within the scatter of the next).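

Going by these compounds alone, this is the first look at the aryl group on the carbonyl carbon, and in this assay the exchange of 4-aminophenyl for 3,4-dichlorophenyl gives a number 2 percentage points lower from compound 2 to compound 3 (within the scatter), so the data show no difference between the two compounds. The exchange is a large one on paper: the group that leaves carries a hydrogen-bond donor and a hydrogen-bond acceptor, the group that enters carries neither and brings two chlorine atoms, yet the read-out stays at the level where cells are essentially unaffected at this single concentration. This position therefore tolerates the change without any visible gain in effect, although a read-out at the top of its range can hide differences that would appear only among more active compounds, and nothing available explains the outcome.

As far as these compounds go, it remains open whether a different group on the same carbonyl carbon, such as a carboxylic acid or a longer alkyl chain, would bring the read-out down. Also open, from the compounds shown here alone, is whether the 4-aminophenyl and 3,4-dichlorophenyl groups would separate at a concentration where the cells respond.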